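Methylsulfonyl in place of trifluoromethyl on the anilino ring

The source may report more compounds than this note shows. Statements on the series, on what has been measured and on what is new or still open speak of the compounds shown alone.

Compound 1 `FC(F)(F)c1ccc(Nc2ncnc3sc(Nc4c(Cl)cccc4Cl)nc23)cc1` gives 3 nM in a functional assay on HEK293 cells for antagonist activity at transient receptor potential cation channel subfamily V member 1 (Rattus norvegicus), read by calcium flux (on this read-out higher numbers stand for weaker inhibition and lower numbers for stronger inhibition), the lowest of the three measured numbers. Compound 2 `CN(c1nc2c(Nc3ccc(C(F)(F)F)cc3)ncnc2s1)c1c(Cl)cccc1Cl` gives 540 nM in this assay; the step of a 180-fold higher number from compound 1 to compound 2 (2.26 log units; beyond the scatter) follows methyl in place of hydrogen on a nitrogen on an aromatic ring. Compound 3 `CS(=O)(=O)c1ccccc1Nc1nc2c(Nc3ccc(C(F)(F)F)cc3)ncnc2s1` gives 221 nM in this assay; the step of a 74-fold higher number from compound 1 to compound 3 (1.87 log units; beyond the scatter) follows 2-(methylsulfonyl)phenyl in place of 2,6-dichlorophenyl on a nitrogen on an aromatic ring.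

Compound 4 `CS(=O)(=O)c1ccc(Nc2ncnc3sc(Nc4c(Cl)cccc4Cl)nc23)cc1` is not yet measured. Its change from compound 1 is methylsulfonyl in place of trifluoromethyl on an aromatic carbon of a six-membered aromatic ring of carbon only, para to a large group. Neither measured step touches this ring: both alter the other nitrogen of the shared core, so neither bears directly on the present change. The one loose link is that compound 3 also carries a methylsulfonyl group, on a different ring, and there the step of a 74-fold higher number from compound 1 to compound 3 (1.87 log units; beyond the scatter) was large; this is weak guidance. A moderate upward step a 10-fold higher number from compound 1 to compound 4 (1.00 log units; beyond the scatter) is therefore expected for compound 4, with wide uncertainty. The estimate for compound 4 in this assay is 30 nM, expected between 5 nM and 300 nM.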

Compound 4, half-maximal inhibitory concentration: 3 nM
Estimate against measurement, compound 4: 10-fold (1.00 log units) above; measured number below the stated range.
By their numbers in this assay, from the lowest: compounds 1 and 4 (each within the scatter of the next); then compound 3; then compound 2.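

In this assay, the exchange of trifluoromethyl for methylsulfonyl on this aromatic carbon, para to a large group, gives no change at the digits printed from compound 1 to compound 4 (within the scatter) and so shows that this place accepts a group other than trifluoromethyl with no readable loss. The two groups have the same count of heavy atoms, but methylsulfonyl brings 2 hydrogen-bond acceptors where trifluoromethyl has 0, so this difference in the group leaves the read-out within the scatter here, and methylsulfonyl as such cannot be held to account for the large step of a 74-fold higher number from compound 1 to compound 3 (1.87 log units; beyond the scatter) seen with 2-(methylsulfonyl)phenyl on the other nitrogen. No measurement at hand accounts for the two groups reading alike at this place.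

The compounds shown leave open whether this tolerance reaches beyond these two groups, for instance to an amine, a carboxylic acid or a longer chain such as ethylsulfonyl on the same aromatic carbon. They also leave open whether methylsulfonyl at this place would read the same with the methyl on the nitrogen of compound 2 or with another group in place of 2,6-dichlorophenyl.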